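The compounds below may be only part of what the source reports. "The series", "measured", "known", "first", "only" and "open" are said of these compounds alone.

Measured in a physicochemical assay for lipophilicity, using the shake flask method, in phosphate buffer, measured as octanol-water partition, with a stated time of 30 min, at pH 7.4; on this read-out higher numbers stand for higher lipophilicity and lower numbers for lower lipophilicity:
- compound 1 `CN(c1ncco1)c1cnc(NCc2c(F)ccc3c2CCO3)n2cnnc12`: 2.1
- compound 2 `O=C1CCCN1c1cnc(NCc2c(F)ccc3c2CCO3)c2cn[nH]c(=O)c12`: 1.8
- compound 3 `CC1(C)CC(=O)N(c2cnc(NCc3c(F)ccc4c3CCO4)n3cnnc23)C1`: 2

The three numbers lie close together, and compound 2, at 1.8, sits within the scatter of both compound 1 and compound 3. The next compound, compound 4 `Cc1ncccc1-c1cnc(NCc2c(F)ccc3c2CCO3)c2cn[nH]c(=O)c12`, keeps the core of compound 2 and carries 2-methylpyridin-3-yl in place of 2-oxopyrrolidin-1-yl on an aromatic carbon.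

Going by the values given here, no measured step involves this exact exchange. The nearest evidence is a single step on a different core, a number 0.10 log units lower from compound 1 to compound 3 (within the scatter), which replaces methyl(1,3-oxazol-2-yl)amino with 4,4-dimethyl-2-oxopyrrolidin-1-yl. It bears on the present change only loosely, and the data fix no direction. Among the compounds with values here, with a number 0.10 log units lower from compound 1 to compound 3 (within the scatter) as the sole guide, no step beyond the scatter is expected in this assay. The estimated step is a number 0.20 log units higher from compound 2 to compound 4 (within the scatter). For compound 4 the expected value is 2, with an estimated range from 1.5 to 2.5.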

Compound 4, distribution coefficient: 3
The estimate for compound 4 lay 1.00 log units below the measured number; the whole stated range lies below it.
By their numbers in this assay, from the lowest: compounds 2, 3 and 1 (each within the scatter of the next); then compound 4.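

On the core of compound 2, the aromatic carbon para to a large group proved able to carry a large change in this assay: the exchange of 2-oxopyrrolidin-1-yl for 2-methylpyridin-3-yl gives a number 1.20 log units higher from compound 2 to compound 4 (beyond the scatter). The only earlier step, a number 0.10 log units lower from compound 1 to compound 3 (within the scatter), was on a different core and stayed within the scatter, so the earlier compounds had shown no change of this size. The two groups have the same counts of hydrogen-bond donors and acceptors but differ in their rings, one five-membered and non-aromatic, the other six-membered and aromatic, and nothing available ties the step to any one of these features.

As far as these compounds go, it remains open how much of the step belongs to the methyl group and how much to the pyridine ring, which a plain pyridin-3-yl or phenyl group at this position would help to separate. From the compounds shown here alone, whether a morpholine or a simple amine there would stay near compound 2 or move towards compound 4 is also open, as is whether the same exchange would give a similar step on the core of compound 1.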